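A few compounds are considered here, and "the series" means these few. Any claim that something is new, unique, unknown or untested is made for them only; others in the source may bear on it.

Three compounds of the series have numbers in an assay on microsomes from liver for inhibition of sterol O-acyltransferase 1 (Rattus norvegicus); on this read-out higher numbers stand for weaker inhibition and lower numbers for stronger inhibition. Compound 1 `O=c1cc(-c2ccccc2)c(-c2ccccc2)nn1C1CCCC1` gives 119000 nM in this assay; compound 2 `CCCCCCn1nc(-c2ccccc2)c(-c2ccccc2)c(C)c1=O` gives 56000 nM. Compound 3 `CCCCCCNc1cc(-c2ccccc2)c(-c2ccccc2)nn1` gives 24000 nM, the lowest of the three, and its steps to compound 2 and compound 1 are both beyond the scatter, so it is the strongest inhibitor among them. The next step to compound 4 `O=C(O)CCCCCSc1cc(-c2ccccc2)c(-c2ccccc2)nn1` is this change: (5-carboxypentyl)sulfanyl in place of hexylamino on an aromatic carbon. Among the measured compounds shown here, no measured pair shows this change, so there is no step to lean on. With compound 3 at 24000 nM, a step of a 1.7-fold higher number from compound 3 to compound 4 (0.22 log units; within the scatter) is expected, toward a weaker number but not clearly beyond the scatter. For compound 4 the estimate is 40000 nM, within 8000 nM to 200000 nM.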

Compound 4, half-maximal inhibitory concentration: > 300000 nM
Compound 4 ended at the assay's limit (the forecaster's own chance of this, stated with the estimate: 20%); at least 7.5-fold (0.87 log units) between middle value and limit.
By their numbers in this assay, from the lowest: compound 3; then compound 2; then compound 1. At a limit, above all of these: compound 4.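

In this assay compound 4 gives a limit, not a number: the limit of > 300000 nM in this assay, at which 1 of the 4 values shown sits. On the aromatic carbon next to the ring nitrogen, (5-carboxypentyl)sulfanyl in place of hexylamino gives an at least 12-fold higher number from compound 3 to compound 4 (1.09 log units; beyond the scatter), so this position responds strongly to what it carries, even with a chain of similar length. This single change swaps the linking atom and the chain end together, and the compounds shown cannot separate the two. Hexylsulfanyl or (5-carboxypentyl)amino at this position would tell them apart, while a terminal amine and a shorter chain remain open.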